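Trimming the aryl ketone to acetyl: expected solubility gain

The compounds below may be only part of what the source reports. "The series", "measured", "known", "first", "only" and "open" are said of these compounds alone.

Compound 1 (`COc1ccc(C(=O)/C=C/c2ccc(OCCNc3ccnc4cc(Cl)ccc34)c(OC)c2)c(OC)c1`) was measured in a physicochemical assay for solubility, in phosphate buffer, at pH 6.5 (a higher number here means a more soluble compound, a lower number a less soluble compound), where compound 1 gives 3.1 ug/mL as the only numerical result among the three compounds. Compound 2 (`COc1ccc(C(=O)/C=C/c2ccc(OCc3cn(-c4ccnc5cc(Cl)ccc45)nn3)c(OC)c2)c(OC)c1`) reaches only the assay limit, with compound 2 reported in this assay as < 1.6 ug/mL rather than as a number. Compound 3 (`COc1ccc(C(=O)/C=C/c2ccc(O)c(CN3CCN(c4ccnc5cc(Cl)ccc45)CC3)c2)c(OC)c1`) is likewise capped, compound 3 being reported in this assay as < 1.6 ug/mL with no number attached. Going by the values given here, compound 1 thus stands as the one quantified value, the other two resting at the limit of < 1.6 ug/mL in this assay, at which 2 of the 3 values shown sit.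

Among the compounds with values here, no two measured compounds differ in a single place, so no measured step exists within the set. The unmeasured compound 4 (`COc1cc(/C=C/C(C)=O)ccc1OCCNc1ccnc2cc(Cl)ccc12`) differs from compound 1 in one place: methyl in place of 2,4-dimethoxyphenyl on a carbonyl carbon. Cut one bond further out, the (2,4-dimethoxyphenyl)carbonyl of compound 1 becomes an acetyl in compound 4. For this change an upward step in this assay beyond the usual scatter is expected, although nothing measured here confirms it. Compound 4 is expected to give 15 ug/mL in this assay, within an estimated range from 4 ug/mL to 60 ug/mL. The step of a 4.8-fold higher number from compound 1 to compound 4 (0.68 log units; beyond the scatter) is accordingly the estimate.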

Compound 4, solubility: 6.3 ug/mL
The estimate for compound 4 lay 2.4-fold (0.38 log units) above the measured number; the range from low to high includes it.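

Going by these compounds alone, compound 4 gives the first reading at a single place in this set: in this assay, the change of 2,4-dimethoxyphenyl to methyl on a carbonyl carbon gives a 2.0-fold higher number from compound 1 to compound 4 (0.31 log units; beyond the scatter). The step is modest but lies beyond the usual scatter, so the direction at this position can be read, even though a whole aromatic ring leaves and only a methyl enters. Compound 4 joins compound 1 as a quantified result, while compounds 2 and 3 remain limits rather than numbers: the limit of < 1.6 ug/mL in this assay, at which 2 of the 4 values shown sit.

What the compounds shown leave open is whether another group on this carbonyl carbon, such as an aminomethyl group or a carboxylic acid, would carry the number further than methyl does in this assay. Within the data shown here, they also leave open whether the same change to acetyl would give a step of similar size on the cores of compound 2 and compound 3, since the one step available rests on the core of compound 1 alone.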